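The source may report more compounds than this note shows. Statements on the series, on what has been measured and on what is new or still open speak of the compounds shown alone.

Of the compounds shown here, three sharing one core have been measured in an ADME assay on BHK15 cells (Mesocricetus auratus) for inhibition, read by XTT assay, with a stated time of 36 h; on this read-out higher numbers stand for weaker inhibition of growth and lower numbers for stronger inhibition of growth. Compound 1 `CONC(=O)c1sc(-c2ccc(Cl)cc2)nc1C(Br)Br` gives 81400 nM. Compound 2 `CCOC(=O)c1sc(-c2ccc(Cl)cc2)nc1C(Br)Br` gives 94600 nM, and compound 3 `CCSC(=O)c1sc(-c2ccc(Cl)cc2)nc1C(Br)Br` gives 81400 nM. On these numbers compound 1 stands level with compound 3, the two together the lowest of the three, with compound 2 the furthest from it; yet every step among them lies within the scatter, as seen in a 1.2-fold higher number from compound 1 to compound 2 (0.07 log units; within the scatter), no change at the digits printed from compound 1 to compound 3 (within the scatter) and a 1.2-fold lower number from compound 2 to compound 3 (0.07 log units; within the scatter).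

Compound 4 `O=C(NCCO)c1sc(-c2ccc(Cl)cc2)nc1C(Br)Br` has not been measured. It differs from compound 1 by 2-hydroxyethyl in place of methoxy on an amide-type nitrogen. The measured steps all exchange the group on the carbonyl carbon rather than on the amide-type nitrogen, so they bear only loosely on this change; what they show is that exchanging a neighbouring group left the number essentially unmoved. On that basis the number for compound 4 is expected to stay close to that of compound 1, with a step of a 1.0-fold higher number from compound 1 to compound 4 (0.00 log units; within the scatter) not beyond the scatter. The estimate for compound 4 is 82000 nM, expected to fall between 30000 nM and 220000 nM.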

Compound 4, concentration for 50% growth inhibition: 40800 nM
The estimate for compound 4 lay 2.0-fold (0.30 log units) above the measured number, within the range that was stated.
By their numbers in this assay, from the lowest: compounds 4, 1, 3 and 2 (each within the scatter of the next, the first and the last beyond it).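

In this assay, the first change made on the amide-type nitrogen itself, 2-hydroxyethyl in place of methoxy, gives a 2.0-fold lower number from compound 1 to compound 4 (0.30 log units; within the scatter), so this position accepts a chain carrying a hydrogen-bond donor without any loss of growth inhibition. Within the data shown here, the comparison with the sulfur-linked group reads the same way, with a 2.0-fold lower number from compound 3 to compound 4 (0.30 log units; within the scatter), whereas a 2.3-fold lower number from compound 2 to compound 4 (0.37 log units; beyond the scatter) is the first step in this small set to pass beyond the scatter, a modest move towards stronger inhibition of growth. Nothing available explains that step.

Going by these compounds, it remains open whether the hydroxyl group or the chain itself matters on this nitrogen, a question that a plain ethyl group would help to settle. A longer chain such as 3-hydroxypropyl, or an amine such as 2-aminoethyl, would show whether the number can move further from here.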